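Swapping the Aryl Group on the Ring Amide Nitrogen

The source may report more compounds than this note shows. Statements on the series, on what has been measured and on what is new or still open speak of the compounds shown alone.

Compound 1 `COc1ccccc1N1C(=O)C(C)SC1c1cccc(C(=O)NCCCCc2ccccc2)c1`: 82%
Compound 2 `COc1cccc(OC)c1N1C(=O)CSC1c1cccc(C(=O)NCCCCc2ccccc2)c1`: 80%

In a functional assay on HOS cells (Homo sapiens) for inhibition, read by CCK-8 assay, with a stated time of 72 h, tested at 1 uM (on this read-out higher numbers stand for more inhibition at the one concentration tested (going by the name of the read-out) and lower numbers for less inhibition), compound 1 gives 82% and compound 2 gives 80%. Compound 2 stands with compound 1: its number is nominally the lower of the two, but the gap to compound 1 falls within the usual scatter, so the two cannot be ranked.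

Compound 3 `COc1cc(F)ccc1N1C(=O)CSC1c1cccc(C(=O)NCCCCc2ccccc2)c1` has not been measured in this assay. It differs from compound 2 in one place: 4-fluoro-2-methoxyphenyl in place of 2,6-dimethoxyphenyl on an amide-type nitrogen in a ring. No step between measured compounds involves this change, so nothing shown tells how it acts; both measured aryl groups on this nitrogen give similar inhibition. Compound 3 is therefore expected to stay close to compound 2, with the step of a number 4 percentage points lower from compound 2 to compound 3 (within the scatter) estimated as small and not beyond the scatter. For compound 3 the estimate is 76%, ranging from 55% to 90%.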

Compound 3, a percentage reported as inhibition, at one concentration (the size of the read-out at that concentration, not a potency): 81%
Compound 3: the middle estimate sits 5 percentage points below what was measured; the measured number falls inside the stated range.
By their numbers in this assay, from the lowest: compounds 2, 3 and 1 (each within the scatter of the next).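

In this assay, going by these compounds alone, 4-fluoro-2-methoxyphenyl in place of 2,6-dimethoxyphenyl on the amide-type nitrogen in the ring gives a number 1 percentage points higher from compound 2 to compound 3 (within the scatter), the first step that can be read at this position. A methoxy group on this aryl ring can therefore give way to a fluorine without the inhibition moving beyond the scatter at the one concentration tested. Nothing measured here accounts for this result.

Every aryl group shown on this nitrogen still carries a methoxy group, so it remains open how the position behaves with plain phenyl or with an aryl group bearing an amine or a carboxylic acid. A reading at one concentration also leaves open whether compound 2 and compound 3 would differ in potency.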